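The source may report more compounds than this note shows. Statements on the series, on what has been measured and on what is new or still open speak of the compounds shown alone.

Measured so far in a functional assay on SiHa cells (Homo sapiens) for cytotoxicity, read by MTT assay, with a stated time of 48 h; a higher number here means a weaker inhibitor, a lower number a stronger inhibitor:
- compound 1, `CCCCCCCCNC(=O)[C@@H](NC(=O)c1ccccc1)[C@@H](C)O`: 112000 nM
- compound 2, `CCCCCCCCCCCCCCNC(=O)[C@@H](NC(=O)c1ccccc1)[C@@H](C)O`: > 200000 nM, a limit of the assay, not a number
- compound 3, `CCCCCCCCCCCCCCNC(=O)[C@@H](NC(=O)c1nccc2ccccc12)[C@@H](C)O`: 21600 nM

Compound 2 stands at the limit of > 200000 nM in this assay, at which 1 of the 3 values shown sits; only a limit is known for it, and the reading for compound 2 is > 200000 nM. Of the two measured steps, an at least 1.7-fold higher number from compound 1 to compound 2 (0.25 log units; that floor lies within the scatter) concerns the chain only and does not touch the acyl side. an at least 9.2-fold lower number from compound 2 to compound 3 (0.96 log units; beyond the scatter) is the step closest in place to the change now considered, since it swaps the group carried on the carbonyl carbon and gives a step beyond the scatter.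

Compound 4, `CCCCCCCCCCCCCCNC(=O)[C@@H](NS(=O)(=O)c1ccc(C)cc1)[C@@H](C)O`, differs from compound 2 by (4-methylphenyl)sulfonyl in place of benzoyl on an amine nitrogen. Among the compounds with values here, no measured step exchanges an amide-type carbonyl for a sulfonyl, so the size of the effect of this change in this assay cannot be read from the series; the one nearby step, from compound 2 to compound 3, shows that a change on this side can move the number by a modest amount. Because compound 2 is known only as a limit, > 200000 nM, the direction is open.

Compound 4 is therefore expected to remain weak, with an estimate of 150000 nM, in the range 40000 nM to 250000 nM. The expected step from compound 2 is an at least 1.3-fold lower number from compound 2 to compound 4 (0.12 log units; that floor lies within the scatter).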

Compound 4, half-maximal inhibitory concentration: 19200 nM
Beside the measured number, compound 4's estimate is 7.8-fold (0.89 log units) above it, outside the stated range (below it).
By their numbers in this assay, from the lowest: compounds 4 and 3 (each within the scatter of the next); then compound 1. At a limit, above all of these: compound 2.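

In this assay, within the data shown here, (4-methylphenyl)sulfonyl in place of benzoyl on the amine nitrogen gives an at least 10-fold lower number from compound 2 to compound 4 (1.01 log units; beyond the scatter), a large step and the only measured exchange of a carbonyl-linked group for a sulfonyl-linked one at this place. With the chain held constant, compound 3 gives 21600 nM and compound 4 gives 19200 nM, values within the scatter of each other, so isoquinolin-1-yl on the carbonyl and the (4-methylphenyl)sulfonyl group on the amine nitrogen reach the same band in this assay. The reading for compound 2 is a limit of the assay, not a number, so the step to compound 4 gives only a floor on the true size: the limit of > 200000 nM in this assay, at which 1 of the 4 values shown sits.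

The compounds shown do not separate the contribution of the sulfonyl from that of the methyl on the ring, which a phenylsulfonyl group and a 4-methylbenzoyl group would do. Also open, as far as these compounds go, are whether the (4-methylphenyl)sulfonyl group gives a comparable reading on the shorter chain of compound 1, and how a ring carrying an amine or a carboxylic acid in place of the methyl would read.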